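Methoxy removal on the thiazole aryl group: expected effect

The source may report more compounds than this note shows. Statements on the series, on what has been measured and on what is new or still open speak of the compounds shown alone.

Two compounds of this series carry numbers in a functional assay on U-87MG ATCC cells for antiproliferative activity against U-87 MG (Homo sapiens), read by MTT assay, with a stated time of 48 h, tested at 10 uM; on this read-out higher numbers stand for a weaker effect at the one concentration tested and lower numbers for a stronger effect. Compound 1 `COc1ccc(-c2nc(SCC(=O)c3sc(-c4ccccc4)nc3C)[nH]c(=O)c2C#N)cc1` gives 90.4% in this assay. Compound 2 `COc1ccc(-c2nc(C)c(C(=O)CSc3nc(-c4cccc(OC)c4)c(C#N)c(=O)[nH]3)s2)cc1` gives 66.7% in this assay, the lower of the two numbers, and the number for compound 1 lies higher by more than the usual scatter. For the measured compounds named here, no single-point change between measured compounds is available, so no measured step can guide the next one directly.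

Compound 3 `COc1cccc(-c2nc(SCC(=O)c3sc(-c4ccccc4)nc3C)[nH]c(=O)c2C#N)c1` differs from compound 2 in one place: hydrogen in place of methoxy on an aromatic carbon. Compound 3 thereby shares with compound 1 the phenyl group on the thiazole and with compound 2 the 3-methoxyphenyl group on the core. Going by the values given here, with only two measured numbers, the size of this step is uncertain; the two numbers suggest it is more likely upward than downward.

The step expected is a number 11.3 percentage points higher from compound 2 to compound 3 (beyond the scatter), upward and of moderate size, though a result within the scatter cannot be ruled out. Compound 3 is expected at 78%, within 58% to 96%.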

Compound 3, a percentage reported as activity, at one concentration (the size of the read-out at that concentration, not a potency): 90.2%
Beside the measured number, compound 3's estimate is 12.2 percentage points below it; measured number inside the range.
By their numbers in this assay, from the lowest: compound 2; then compounds 3 and 1 (each within the scatter of the next).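

For the compounds shown here, the change from 4-methoxyphenyl to phenyl gives the first single-place step in this assay, and it reads a number 23.5 percentage points higher from compound 2 to compound 3 (beyond the scatter) for this methoxy, para to a large group, so in this pair the read-out does respond to what stands at this position. With phenyl in that place, 3-methoxyphenyl in place of 4-methoxyphenyl on the other aryl group reads a number 0.2 percentage points lower from compound 1 to compound 3 (within the scatter), so the two methoxy placements on that ring cannot be told apart in this assay pair, and a response to the methoxy on one aryl group need not carry over to the other. No measurement in hand accounts for the step at the 4-methoxyphenyl position.

Going by these compounds, whether the stronger effect of compound 2 belongs to methoxy in particular or to any group at this position stays open, and an amine, a carboxylic acid or a longer chain such as ethoxy in the same place would begin to separate those readings. Also open is whether the 4-methoxyphenyl on this side would behave the same with 4-methoxyphenyl rather than 3-methoxyphenyl on the core, since only one such background is shown.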